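From 4-methylpiperazin-1-yl to morpholin-4-yl on a carbonyl carbon

The source may hold more compounds than are shown below. What is called first, only, known or untested is meant among the compounds shown, and "the series" means these compounds.

In a functional assay on MDA-MB-231 cells (Homo sapiens) for inhibition, read by sulforhodamine B assay, with a stated time of 72 h (on this read-out higher numbers stand for weaker inhibition of growth and lower numbers for stronger inhibition of growth), compound 1 `CN1CCN(C(=O)/C=C/c2ccncc2-c2ccc3ccccc3c2)CC1` reads > 10000 nM, which is a limit and not a number. Compound 2 `Cn1ncc2cc(-c3cnccc3/C=C/C(=O)O)ccc21` reads > 10000 nM, which is also a limit. Going by the values given here, compound 3 `CCOC(=O)/C=C/c1ccncc1-c1ccc2c(ccn2C)c1` gives the only actual number so far, 10200 nM. Compound 1 therefore stands at the limit of > 10000 nM in this assay, at which 2 of the 3 values shown sit.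

Compound 4 `O=C(/C=C/c1ccncc1-c1ccc2ccccc2c1)N1CCOCC1` has not been measured. Its difference from compound 1 is counted as follows (morpholin-4-yl in place of 4-methylpiperazin-1-yl on a carbonyl carbon): morpholin-4-yl in place of 4-methylpiperazin-1-yl on a carbonyl carbon. Each group is one six-membered non-aromatic ring with 2 hetero atoms and no net charge.

Among the compounds with values here, no measured pair gives a step for this change, and compound 1 offers a limit as its starting point. No step beyond the usual scatter is expected in this assay, and neither direction is favoured. This expectation rests on the limit of compound 1, > 10000 nM. The estimated change is a step that the limit leaves unreadable from compound 1 to compound 4, and a report of only a limit is considered likely. For compound 4 the expected value is 12000 nM, with an estimated range of 5000 nM to 30000 nM.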

Compound 4, concentration for 50% growth inhibition: 8980 nM
Compound 4: the middle estimate sits 1.3-fold (0.13 log units) above what was measured; the measured number falls inside the stated range.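

Compound 1 reads > 10000 nM in this assay, which is a limit and not a number. Going by these compounds alone, the change to morpholin-4-yl on a carbonyl carbon gives the first step, an at least 1.1-fold lower number from compound 1 to compound 4 (0.04 log units; that floor lies within the scatter), and so the first reading for this position that is tied to a single change. Compound 4 gives 8980 nM, a number for this amide. The 4-methylpiperazin-1-yl amide gave only a limit, and the step has a floor and no upper end, so its true size stays unread: the limit of > 10000 nM in this assay, at which 2 of the 4 values shown sit.

The notes cannot yet say whether the real gap between these two amides lies within or beyond the scatter, and a pair with both members read as numbers would be needed to settle that. Also open, from the compounds shown here alone, is how other groups on the same carbonyl carbon would read on this core, for example a piperidin-1-yl ring, which has no second hetero atom, or an open-chain dimethylamino group.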